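Amide replacement on a hexafluoroisopropanol naphthalene urea scaffold

The source may hold more compounds than are shown below. What is called first, only, known or untested is meant among the compounds shown, and "the series" means these compounds.

Measured so far:
compound 1, `O=C(NCCCCCCCl)Nc1c(C(O)(C(F)(F)F)C(F)(F)F)ccc2ccccc12`: 4840 nM
compound 2, `O=C(Nc1c(C(O)(C(F)(F)F)C(F)(F)F)ccc2ccccc12)c1ccc(I)cc1`: 154 nM

For the measured compounds named here, in an assay on LtK cells with ATP-sensitive inward rectifier potassium channel 11 (Homo sapiens) as the target (a higher number here means that more compound is needed for the effect, a lower number that less compound is needed), compound 2 gives the lowest of the two numbers; its only neighbour is compound 1, and the step of a 31-fold lower number from compound 1 to compound 2 (1.50 log units; beyond the scatter) separates them. Compound 3, `O=C(Nc1c(C(O)(C(F)(F)F)C(F)(F)F)ccc2ccccc12)c1cnco1`, has not yet been measured. It differs from compound 2 in one place: 1,3-oxazol-5-yl in place of 4-iodophenyl on a carbonyl carbon. Going by the values given here, the one step that bears on this position is the replacement of (6-chlorohexyl)amino by 4-iodophenyl, a 31-fold lower number from compound 1 to compound 2 (1.50 log units; beyond the scatter), which shows that what sits on the carbonyl carbon governs the read-out strongly. Among the compounds with values here, no measured pair shows a six-membered aromatic ring of carbon only giving way to a five-membered aromatic ring with two hetero atoms, so the direction rests on the size of that single step alone. Compound 3 is therefore expected to show a higher number than compound 2, a step of about a 6.5-fold higher number from compound 2 to compound 3 (0.81 log units; beyond the scatter), and an estimated value of 1000 nM, within a range of 300 nM to 4000 nM.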

Compound 3, half-maximal effective concentration: 24 nM
Beside the measured number, compound 3's estimate is 42-fold (1.62 log units) above it; measured number below the stated range.
By their numbers in this assay, from the lowest: compound 3; then compound 2; then compound 1.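

In this assay, the step of a 6.4-fold lower number from compound 2 to compound 3 (0.81 log units; beyond the scatter) shows that the 4-iodophenyl group is not needed for a low number on this carbonyl carbon: the 1,3-oxazol-5-yl ring, with fewer heavy atoms and with 2 hydrogen-bond acceptors where the 4-iodophenyl has none, does better. Set against the (6-chlorohexyl)amino group, the same ring gives a 200-fold lower number from compound 1 to compound 3 (2.30 log units; beyond the scatter) and so widens the span seen at this position, with both aromatic rings well ahead of the chain-bearing urea. Nothing measured here accounts for the advantage of the five-membered ring.

The compounds shown leave open whether the iodine, the ring size or the hetero atoms carry the step. As far as these compounds go, how a plain phenyl, a furan or a thiazole would read on the same carbonyl carbon also remains open.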